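This account rests on a few compounds, and the source may have more. Where it says the series, first, only, none or still open, it means among the compounds named here.

Compound 1 `CN1Cc2ccc(OCc3ccc(Br)cc3)cc2[C@@H](O)C1` and compound 2 `CN1Cc2ccc(OCc3cccc(Br)c3)cc2[C@@H](O)C1` are built from the same core and differ only in how the bromine is placed: 3-bromophenyl in place of 4-bromophenyl on a saturated chain carbon bound to an oxygen on an aromatic ring. In an ADME assay on Vero cells (Chlorocebus sabaeus) for cytotoxicity, read by sulforhodamine B assay, with a stated time of 72 h (a lower number here means a stronger inhibitor, a higher number a weaker inhibitor), compound 1 gives 37000 nM, and compound 2 gives 60300 nM, a step of a 1.6-fold higher number from compound 1 to compound 2 (0.21 log units; within the scatter). Compound 3 `COc1cccc(-c2ccc(COc3ccc4c(c3)[C@@H](O)CN(C)C4)cc2)c1` is compound 1 after a larger change, (3-methoxyphenyl in place of bromo on an aromatic carbon); in this assay compound 3 gives 10800 nM, which is a 3.4-fold lower number from compound 1 to compound 3 (0.53 log units; beyond the scatter). Compound 4 `COc1cccc(-c2cccc(COc3ccc4c(c3)[C@@H](O)CN(C)C4)c2)c1` has not yet been measured. It carries the same kind of change relative to compound 2, (3-methoxyphenyl in place of bromo on an aromatic carbon), but here the new group sits meta to a large group, whereas in compound 3 it sits para to a large group. Compound 4 is expected to move a 3.4-fold lower number from compound 2 to compound 4 (0.53 log units; beyond the scatter), close to the earlier step of a 3.4-fold lower number from compound 1 to compound 3 (0.53 log units; beyond the scatter), since both rest on the same exchange. The estimate for compound 4 is 18000 nM, between 8000 nM and 40000 nM.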

Compound 4, half-maximal inhibitory concentration: 24300 nM
For compound 4 the middle estimate is 1.4-fold (0.13 log units) below the measured one, within the range that was stated.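

Putting 3-methoxyphenyl in place of bromo gives a 2.5-fold lower number from compound 2 to compound 4 (0.39 log units; beyond the scatter) in this assay. For the compounds shown here, the same exchange therefore lowers the number on both cores, and the two steps cannot be told apart: the same change on two cores in this assay, a 3.4-fold lower number (0.53 log units; beyond the scatter) from compound 1 to compound 3 and a 2.5-fold lower number (0.39 log units; beyond the scatter) from compound 2 to compound 4, 1.4-fold (0.14 log units) apart, within the scatter of two such steps This rests on only two pairs of compounds, which differ in where the bromine sat, so it shows the exchange carrying over between these two cores in this assay, but not that it would hold on other cores or in other assays, nor why the number falls.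

Going by these compounds, it remains open how much of each step comes from the added ring and how much from its methoxy group. A plain phenyl, or a phenyl carrying an amine or a carboxylic acid in place of the methoxy, could separate the two.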